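Sulfonyl substituent change on the ring amine nitrogen

This account rests on a few compounds, and the source may have more. Where it says the series, first, only, none or still open, it means among the compounds named here.

Measured so far in an assay on HEK293 cells for positive allosteric modulation of metabotropic glutamate receptor 5 (Homo sapiens), read by FLIPR, with a stated time of 1 h; on this read-out higher numbers stand for an effect only at larger amounts of compound and lower numbers for an effect already at smaller amounts:
compound 1 `CC1CC1C(=O)N1CCc2nc(C#Cc3ccccc3)sc2C1` gives 9.4 nM
compound 2 `CC(C)S(=O)(=O)N1CCc2nc(C#Cc3ccccc3)sc2C1` gives > 10000 nM

Compound 2 stands at the limit of this assay and has no number of its own, only (the limit of > 10000 nM in this assay, at which 1 of the 2 values shown sits). Compound 3 `O=S(=O)(N1CCCCC1)N1CCc2nc(C#Cc3ccccc3)sc2C1` differs from compound 2 by piperidin-1-yl in place of isopropyl on a sulfonyl sulfur. The only measured step, an at least 1000-fold higher number from compound 1 to compound 2 (3.02 log units; beyond the scatter), exchanges (2-methylcyclopropyl)carbonyl for isopropylsulfonyl and so speaks to the sulfonyl itself, not to the group on its sulfur; no measured pair varies that group, so the step from compound 2 to compound 3 is untested by the data shown. Since compound 3 keeps the sulfonyl that left compound 2 at the limit, the expected step of a number no higher from compound 2 to compound 3 (the limit leaves the size open) is none beyond the scatter, with a real chance that this assay again reports only a limit. The estimate for compound 3 is 10000 nM, in the range 2500 nM to 40000 nM.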

Compound 3, half-maximal effective concentration: > 10000 nM
Compound 3 gave a limit, no number; the forecaster's own chance of this, stated with the estimate: 65%; the middle value lies on the limit itself.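

In this assay compound 3 gives > 10000 nM, a limit and not a number. Compound 2 also stands at a limit, so no step can be read between compound 2 and compound 3: the limit of > 10000 nM in this assay, at which 2 of the 3 values shown sit.

The compounds shown leave open whether any group on a sulfonyl sulfur gives a measurable number in this assay.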